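The source may hold more compounds than are shown below. What is called first, only, known or untested is meant among the compounds shown, and "the series" means these compounds.

Measured compounds in an assay on isolated protein (artery, Oryctolagus cuniculus) with Substance-P receptor (Homo sapiens) as the target; on this read-out lower numbers stand for tighter binding and higher numbers for weaker binding:

- compound 1 `O=C1CCC(CCN2CC(N3CCOCC3=O)C2)(c2ccc(Cl)c(Cl)c2)CN1Cc1ccccc1`, 2.51 nM
- compound 2 `O=C1CCC(CCN2CC(N3CCNCC3)C2)(c2ccc(Cl)c(Cl)c2)CN1CC1CC1`, 12.6 nM
- compound 3 `CNS(=O)(=O)N1CCN(C2CN(CCC3(c4ccc(Cl)c(Cl)c4)CCC(=O)N(CC4CC4)C3)C2)CC1`, 3.16 nM

Compound 3 holds the second highest of the three numbers in this assay. Its gap to compound 1 lies within the scatter, so the two cannot be ordered; compound 2 stands beyond the scatter with the higher number. Among the compounds with values here, the only step in the set that touches the four-membered ring substituent is a 4.0-fold lower number from compound 2 to compound 3 (0.60 log units; beyond the scatter), where methylsulfamoyl in place of hydrogen on the ring amine nitrogen gives a modest lowering.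

Compound 4 `O=C(O)C1CCN(C2CN(CCC3(c4ccc(Cl)c(Cl)c4)CCC(=O)N(CC4CC4)C3)C2)CC1` differs from compound 3 by 4-carboxypiperidin-1-yl in place of 4-(methylsulfamoyl)piperazin-1-yl on a saturated ring carbon. Within the data shown here, no measured pair carries a carboxylic acid, so there is no direct precedent for this change. What the data show is that the substituent on the four-membered ring tolerates both a free ring amine and a methylsulfamoyl piperazine within a narrow band, the whole spread of this assay being small. The carboxypiperidine keeps one donor and gives up one acceptor relative to what leaves; the step from compound 3 to compound 4 is therefore expected to be small, near or just beyond the scatter, more likely toward a higher number, as a 2.0-fold higher number from compound 3 to compound 4 (0.30 log units; within the scatter).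

Compound 4 is estimated at 6.3 nM in this assay, with a range from 1.6 nM to 25 nM.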

Compound 4, dissociation constant: 0.398 nM
Compound 4: middle estimate off by 16-fold (1.20 log units), on the high side, and the stated range ends above it.
By their numbers in this assay, from the lowest: compound 4; then compounds 1 and 3 (each within the scatter of the next); then compound 2.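

In this assay, the substituent on the saturated ring carbon of the four-membered ring proves able to move the number well beyond the scatter: with 4-carboxypiperidin-1-yl in place of 4-(methylsulfamoyl)piperazin-1-yl, the result is a 7.9-fold lower number from compound 3 to compound 4 (0.90 log units; beyond the scatter). Within the data shown here, measured against the unsubstituted piperazin-1-yl of compound 2, the same group gives a 32-fold lower number from compound 2 to compound 4 (1.50 log units; beyond the scatter), the only step rated large among the three compounds that share this core. The earlier step showed a lowering from a group added to the ring amine nitrogen of the piperazine, whereas this change shows that a further lowering is reached with a carboxylic acid on a six-membered ring with one hetero atom.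

No measurement shown offers an explanation for these steps. On these data alone, the carboxylic acid and the change of ring enter together, so their shares remain open; a methyl ester or a primary amide on the same piperidine, or a carboxylic acid carried on a piperazine, would separate the two in this assay.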